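Swapping methoxy for chloro on a low-clearance compound

The source may report more compounds than this note shows. Statements on the series, on what has been measured and on what is new or still open speak of the compounds shown alone.

Compound 1 `CCCC(Oc1ccc(-n2cc(OC)cn2)cc1)c1ccc(C(=O)NCCC(=O)O)cc1` sits at the low end of an ADME assay on microsomes from liver (Homo sapiens) for metabolic stability; on this read-out higher numbers stand for fast clearance and lower numbers for slow clearance. In this assay compound 1 gives < 8 mL/min/kg, which is a limit of the assay and not a number. Compound 2 `CC(C)(C)C(Oc1ccc(-n2cc(C(F)(F)F)cn2)cc1)c1ccc(C(=O)NCCC(=O)O)cc1` gives a measured 31 mL/min/kg in this assay. Compound 3 `CCCC(Oc1ccc(-n2cc(Cl)cn2)cc1)c1ccc(C(=O)NCCC(=O)O)cc1` has not yet been measured. It keeps the core of compound 1 but carries chloro in place of methoxy on an aromatic carbon, so that 4-methoxy-1H-pyrazol-1-yl becomes 4-chloro-1H-pyrazol-1-yl (chloro in place of methoxy on an aromatic carbon). Within the data shown here, no measured pair in this small set shows this change, so the expectation is a cautious one. A modest move towards faster clearance in this assay is expected, with an estimated at least 1.3-fold higher number from compound 1 to compound 3 (0.13 log units; that floor lies within the scatter), and this may not exceed the usual scatter. For compound 3 the expected clearance is 11 mL/min/kg, within an estimated range of 5 mL/min/kg to 24 mL/min/kg.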

Compound 3, clearance: 10 mL/min/kg
Compound 3: middle estimate off by 1.1-fold (0.04 log units), on the high side; the range from low to high includes it.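

The change from 4-methoxy-1H-pyrazol-1-yl to 4-chloro-1H-pyrazol-1-yl gives, in this assay, an at least 1.2-fold higher number from compound 1 to compound 3 (0.09 log units; that floor lies within the scatter), so this pair shows no clear rise in clearance. Among these compounds, on this aromatic carbon of the five-membered ring, chloro also gives the first measured number on the core of compound 1, with compound 3 at 10 mL/min/kg. The true size of the step remains unknown because compound 1 is known only through a limit: the limit of < 8 mL/min/kg in this assay, at which 1 of the 3 values shown sits.

From the compounds shown here alone, whether a nitrile or an amine on the same carbon would give a similar clearance remains open. Compound 2 differs from compound 3 in more than one place, so the compounds shown also leave open whether chloro in place of trifluoromethyl would give a similar clearance on the core of compound 2.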